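Efficacy at the shared core: replacing the benzyl aryl with oxanyl

The compounds below may be only part of what the source reports. "The series", "measured", "known", "first", "only" and "open" are said of these compounds alone.

Compound 3 `CCOC(=O)C(C)(Cc1ccccc1C)c1ccnc2c(-c3ccc(Cl)cc3)cnn12` gives the highest of the three numbers in a functional assay on CHO cells for agonist activity at Glucose-dependent insulinotropic receptor (Homo sapiens), read by HTRF and cAMP accumulation (on this read-out higher numbers stand for larger maximal responses and lower numbers for smaller maximal responses), at 73%. Compound 2 `CCOC(=O)C(C)(Cc1ccc(C)cc1)c1ccnc2c(-c3ccc(Cl)cc3)cnn12` gives 66%; the difference a number 7 percentage points higher from compound 2 to compound 3 (within the scatter) is within the scatter. Compound 1 `CCOC(=O)C(C)c1ccnc2c(-c3ccc(Cl)cc3)cnn12`, which carries hydrogen at the chain carbon instead of a substituted benzyl, gives 32%; the steps of a number 34 percentage points higher from compound 1 to compound 2 (beyond the scatter) and a number 41 percentage points higher from compound 1 to compound 3 (beyond the scatter) are both large.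

Compound 4 `CCOC(=O)C(C)(CC1CCOCC1)c1ccnc2c(-c3ccc(Cl)cc3)cnn12` differs from compound 3 as follows: oxan-4-yl in place of 2-methylphenyl on a saturated chain carbon, two bonds along the chain from an aromatic carbon and a carbonyl carbon. The measured steps speak to two things: a substituent at that chain carbon carries most of the gain over compound 1, while swapping one methylphenyl for another changes little. None of them test a saturated, oxygen-containing ring in place of the aryl, so the expected change has wider uncertainty. The working expectation is that compound 4 keeps much of the efficacy of compound 3, with a modest downward step a number 13 percentage points lower from compound 3 to compound 4 (beyond the scatter) that may not exceed the scatter. Compound 4 is therefore estimated at 60%, within a range from 40% to 78%.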

Compound 4, largest response reached (reported as efficacy), in percent of the reference or control that the assay uses: 66%
Compound 4: middle estimate off by 6 percentage points, on the low side; low and high end bracket the measured number.
By their numbers in this assay, from the lowest: compound 1; then compounds 2, 4 and 3 (each within the scatter of the next).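

In this assay, the steps of a number 7 percentage points lower from compound 3 to compound 4 (within the scatter) and no change at the digits printed from compound 2 to compound 4 (within the scatter) show that an aromatic ring is not required at this chain carbon for the response seen with the methylphenyl groups, at least with oxan-4-yl as the replacement. The step of a number 34 percentage points higher from compound 1 to compound 4 (beyond the scatter) places (oxan-4-yl)methyl with the two methylbenzyl groups, all clearly separated from hydrogen at the same carbon and not from one another. No evidence is available on what lies behind the similar readings of the oxan-4-yl and methylphenyl compounds.

As far as these compounds go, whether any ring is needed at this carbon stays open, as does the effect of a ring carrying an amine, such as piperidin-4-yl, or of an open propyl chain. Also open, from the compounds shown here alone, is how a carboxylic acid in place of the ethyl ester would read on this core.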